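Amide variations on a shared core

This account rests on a few compounds, and the source may have more. Where it says the series, first, only, none or still open, it means among the compounds named here.

Compound 1 `CCN(CC)C(=O)C(C)N1CCN(S(=O)(=O)c2ccc(C(C)(C)C)cc2)CC1`: in an ADME assay on HepG2 cells (Homo sapiens) for inhibition, with a stated time of 48 h (a lower number here means that less compound is needed, a higher number that more compound is needed for the effect), compound 1 gives > 40000 nM, which is a limit of the assay and not a number.
Compound 2 `CC(C(=O)N1CC2CC2C1)N1CCN(S(=O)(=O)c2ccc(C(C)(C)C)cc2)CC1`: in this assay compound 2 gives > 40000 nM, again a limit of the assay.

Compound 2 therefore stands at the limit, as does every value shown so far (the limit of > 40000 nM in this assay, at which 2 of the 2 values shown sit). For the measured compounds named here, the one step recorded, a step that the two limits leave unreadable from compound 1 to compound 2, runs between two limits and its size cannot be read.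

Compound 3 `CC(C(=O)N1CCC2(CC1)CC2)N1CCN(S(=O)(=O)c2ccc(C(C)(C)C)cc2)CC1` changes the amide part of compound 2: a group of 8 heavy atoms (7 carbon, 1 nitrogen; one three-membered non-aromatic ring of carbon only, one six-membered non-aromatic ring with 1 hetero atom) in place of a group of 6 heavy atoms (5 carbon, 1 nitrogen; one three-membered non-aromatic ring of carbon only, one five-membered non-aromatic ring with 1 hetero atom), on a carbonyl carbon. Going by the values given here, the only measured step that touches the same carbonyl carbon, a step that the two limits leave unreadable from compound 1 to compound 2, is unreadable, so it gives no size and no direction for the present change; no other step bears on it.

Compound 3 is accordingly expected to give 60000 nM, with a range from 20000 nM to 200000 nM, most probably reported once more as a limit. The expected step that the limit leaves unreadable from compound 2 to compound 3 is nominal, as nothing measured points beyond the scatter in either direction.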

Compound 3, half-maximal effective concentration: > 40000 nM
Compound 3 ended at the assay's limit; the forecaster's own chance of this, stated with the estimate: 85%; the middle value lies beyond the limit too.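

The steps among compound 1, compound 2 and compound 3 cannot be read, as all three values are limits and not numbers: the limit of > 40000 nM in this assay, at which 3 of the 3 values shown sit.

The compounds shown leave open how these amide variations compare in this assay, and whether any amide on the shared core gives a measurable half-maximal effective concentration.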